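A Methyl for Chlorine on the Sulfonamide Nitrogen

The compounds below may be only part of what the source reports. "The series", "measured", "known", "first", "only" and "open" are said of these compounds alone.

Measured compounds:
compound 1, `O=C(Nc1cccc(S(=O)(=O)Nc2ccccc2)c1)c1ccc(Cl)cc1Cl`: > 100000 nM
compound 2, `O=C(Nc1ccc(S(=O)(=O)Nc2cccc(Cl)c2)cc1)c1ccc(Cl)cc1Cl`: 575 nM
compound 3, `N#Cc1ccc(C(=O)Nc2ccc(S(=O)(=O)Nc3ccccc3)cc2)c(F)c1`: 229 nM

Of the compounds shown here, three have been tested in a functional assay on HEK293 cells for agonist activity at probable G-protein coupled receptor 27 (Homo sapiens), read by a luciferase reporter and beta-arrestin recruitment, with a stated time of 10 min; on this read-out higher numbers stand for an effect only at larger amounts of compound and lower numbers for an effect already at smaller amounts. For compound 1 the read-out is a limit rather than a number, namely > 100000 nM, which is the limit of > 100000 nM in this assay, at which 1 of the 3 values shown sits. Among the two numbers that remain, compound 2 gives the higher one, 575 nM. Its nearest neighbour is compound 3, whose value in this assay is 229 nM, a lower number by a gap that lies beyond the usual scatter.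

Compound 4, `Cc1ccccc1NS(=O)(=O)c1ccc(NC(=O)c2ccc(Cl)cc2Cl)cc1`, is not yet measured. It differs from compound 2 in one place: 2-methylphenyl in place of 3-chlorophenyl on a sulfonamide nitrogen. Among the measured compounds shown here, no measured pair shows this change, so no step can be read off. The expectation is a step from compound 2 to compound 4 of about a 1.4-fold higher number from compound 2 to compound 4 (0.14 log units; within the scatter) in this assay, that is, no shift clearly beyond the scatter, with a slight lean toward a higher number. Compound 4 is therefore estimated at 800 nM in this assay, within a range from 200 nM to 4000 nM.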

Compound 4, half-maximal effective concentration: 1230 nM
The estimate for compound 4 lay 1.5-fold (0.19 log units) below the measured number; the range from low to high includes it.
By their numbers in this assay, from the lowest: compound 3; then compound 2; then compound 4. At a limit, above all of these: compound 1.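

In this assay, among the compounds shown here, the group on the sulfonamide nitrogen gives the first step that can be read at one place: 2-methylphenyl in place of 3-chlorophenyl produces a 2.1-fold higher number from compound 2 to compound 4 (0.33 log units; beyond the scatter), so this position responds to the change, though only modestly. Compound 4 still gives a number rather than a limit, which shows that a compound in this series can lose the chlorine of 3-chlorophenyl and retain a measurable effect. The group and its place on the ring change together. This one step cannot be divided between the two. Nothing measured here gives a cause for the step. The compounds shown leave open how 3-methylphenyl or 2-chlorophenyl would read at this nitrogen, which would separate the two changes, and how a methoxy group would compare.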